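This account rests on a few compounds, and the source may have more. Where it says the series, first, only, none or still open, it means among the compounds named here.

Measured in a functional assay on MDA-MB-231 cells (Homo sapiens) for antiproliferative activity, with a stated time of 4 days; on this read-out lower numbers stand for stronger inhibition and higher numbers for weaker inhibition:
- compound 1 (`CCCCCc1ccc2[nH]c(-c3ccc(OC)cc3)c(C=C(C#N)C#N)c2c1`): 42 nM
- compound 2 (`CCCCc1ccc2[nH]c(-c3ccc(C(F)(F)F)cc3)c(C=C(C#N)C#N)c2c1`): 56 nM

Only these two numbers exist so far, and compound 2 stands within the usual scatter of compound 1. Compound 3 (`CCCCCc1ccc2[nH]c(-c3ccc(C(F)(F)F)cc3)c(C=C(C#N)C#N)c2c1`) has not yet been measured. It departs from compound 2 by one change: methyl in place of hydrogen on a saturated chain carbon, four bonds along the chain from an aromatic carbon. Among the measured compounds shown here, no measured pair isolates this change, so the data give no direct size for it. In this assay no step beyond the scatter is expected, and no direction is favoured, though compound 2 at 56 nM offers the closest anchor. The expected change is a 1.1-fold lower number from compound 2 to compound 3 (0.05 log units; within the scatter). For compound 3 the estimated value is 50 nM, with an expected range of 22 nM to 110 nM.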

Compound 3, half-maximal inhibitory concentration: 78 nM
Beside the measured number, compound 3's estimate is 1.6-fold (0.19 log units) below it; the measured number falls inside the stated range.
By their numbers in this assay, from the lowest: compounds 1, 2 and 3 (each within the scatter of the next).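

In this assay, among the compounds shown here, the change of methyl in place of hydrogen on a saturated chain carbon, four bonds along the chain from an aromatic carbon, now has a direct size for the first time: a 1.4-fold higher number from compound 2 to compound 3 (0.14 log units; within the scatter). With that chain held constant, trifluoromethyl in place of methoxy on an aromatic carbon also has its first isolated measure, a 1.9-fold higher number from compound 1 to compound 3 (0.27 log units; within the scatter), so neither single change moves the number beyond the scatter. No available evidence bears on why these steps have the sizes they do.

The compounds shown leave open whether a longer chain such as hexyl, or a chain ending in an amine, would give a step beyond the scatter at this position. They also leave open what a carboxylic acid would do on that aromatic carbon in place of trifluoromethyl or methoxy.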